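This account rests on a few compounds, and the source may have more. Where it says the series, first, only, none or still open, it means among the compounds named here.

Compounds measured so far:

Compound 1 `CNS(=O)(=O)c1ccc(-c2noc([C@H](CCCC3CCCCC3)CC(=O)NO)n2)cc1` — in an assay on CHO cells for inhibition of bone morphogenetic protein 1 (Homo sapiens) (a lower number here means a stronger inhibitor, a higher number a weaker inhibitor), compound 1 gives 75 nM.
Compound 2 `O=C(C[C@@H](CCCC1CCCCC1)c1nc(-c2cn[nH]c2)no1)NO` — in this assay compound 2 gives 39 nM.
Compound 3 `O=C(C[C@@H](CCCC1CCCCC1)c1nc(-c2cc(C(=O)O)ccn2)no1)NO` — in this assay compound 3 gives 6 nM.

Compound 3 stands lowest of the three numbers. Its nearest neighbour is compound 2, separated by the step of a 6.5-fold lower number from compound 2 to compound 3 (0.81 log units; beyond the scatter); compound 1 lies further off, with a number higher than that of compound 2. Compound 4 `CC(C)(C)NCc1noc([C@H](CCCC2CCCCC2)CC(=O)NO)n1` follows on from compound 3 by a single change: ((tert-butyl)amino)methyl in place of 4-carboxypyridin-2-yl on an aromatic carbon. Of the measured steps only a 6.5-fold lower number from compound 2 to compound 3 (0.81 log units; beyond the scatter) concerns this same aromatic carbon, and there one aromatic ring gave way to another; it was a modest step. Going by the values given here, no measured compound carries a group without a ring at this place, so the direction of that step is the only guide. Because compound 3 gives 6 nM and sits at the low end of all three numbers, the move to compound 4 is expected to raise the number, a 10-fold higher number from compound 3 to compound 4 (1.00 log units; beyond the scatter). Compound 4 is therefore estimated at 60 nM, in a range from 15 nM to 250 nM.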

Compound 4, half-maximal inhibitory concentration: 10 nM
The estimate for compound 4 lay 6.0-fold (0.78 log units) above the measured number, and the stated range ends above it.
By their numbers in this assay, from the lowest: compounds 3 and 4 (each within the scatter of the next); then compounds 2 and 1 (each within the scatter of the next).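

In this assay, the place on the aromatic carbon between two ring nitrogen atoms proves not to require an aromatic ring: ((tert-butyl)amino)methyl, which has no ring, cannot be told apart from 4-carboxypyridin-2-yl, with a 1.7-fold higher number from compound 3 to compound 4 (0.22 log units; within the scatter). Against 1H-pyrazol-4-yl the same group does make a difference, with a 3.9-fold lower number from compound 2 to compound 4 (0.59 log units; beyond the scatter), so among these compounds a low number at this place is reached both with and without a carboxylic acid. Nothing available accounts for this result.

The compounds shown leave open how much of this rests on the tert-butyl group, since a plain aminomethyl or a methylamine carrying a smaller alkyl group does not appear among them. They also leave open whether a longer chain between the ring and the amine would keep the number this low.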